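Dimethoxy versus trimethoxy on the pyrazole aryl of enone series

The source may report more compounds than this note shows. Statements on the series, on what has been measured and on what is new or still open speak of the compounds shown alone.

Measured compounds:
compound 1 `COc1cc(-c2cc(/C=C/C(=O)c3ccc(N)cc3)[nH]n2)cc(OC)c1OC`: > 100000 nM
compound 2 `COc1ccc(-c2cc(/C=C/C(=O)c3ccc(N)cc3)[nH]n2)cc1OC`: 33000 nM
compound 3 `COc1cc(C(=O)/C=C/c2cc(-c3cc(OC)c(OC)c(OC)c3)n[nH]2)cc(OC)c1OC`: 7190 nM

In a functional assay on HCT-15 cells (Homo sapiens) for inhibition, read by sulforhodamine B assay, with a stated time of 48 h (on this read-out lower numbers stand for higher toxicity in this test and higher numbers for lower toxicity in this test), compound 1 gives only a limit of the assay, > 100000 nM (the limit of > 100000 nM in this assay, at which 1 of the 3 values shown sits). Compound 2 gives 33000 nM in this assay. The change from compound 1 to compound 2 is hydrogen in place of methoxy on an aromatic carbon, and it brings an at least 3.0-fold lower number from compound 1 to compound 2 (0.48 log units; beyond the scatter); as compound 1 sits at a limit, this size is a lower bound. Compound 3 gives 7190 nM in this assay, the lowest number among the two measured numbers; the difference between its core and that of compound 1 is not broken down here.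

Compound 4 `COc1ccc(-c2cc(/C=C/C(=O)c3cc(OC)c(OC)c(OC)c3)[nH]n2)cc1OC` is not yet measured. It differs from compound 3 by hydrogen in place of methoxy on an aromatic carbon, the same change as from compound 1 to compound 2, at the same surroundings. For compound 4 the step is expected to be a 2.9-fold lower number from compound 3 to compound 4 (0.46 log units; beyond the scatter), resting on the measured at least 3.0-fold lower number from compound 1 to compound 2 (0.48 log units; beyond the scatter). In this assay compound 4 is expected to give 2500 nM, with a range from 800 nM to 8000 nM.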

Compound 4, concentration lethal to 50% of the cells: > 100000 nM
Compound 4 ended at the assay's limit; the forecaster's own chance of this, stated with the estimate: 5%; at least 40-fold (1.60 log units) between middle value and limit.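

In this assay, hydrogen in place of methoxy on an aromatic carbon gives an at least 13-fold higher number from compound 3 to compound 4 (1.14 log units; beyond the scatter), which runs opposite to the step on the other core: the same change on two cores in this assay, an at least 3.0-fold lower number (0.48 log units; beyond the scatter) from compound 1 to compound 2 and an at least 13-fold higher number (1.14 log units; beyond the scatter) from compound 3 to compound 4, at least 42-fold (1.62 log units) apart, beyond the scatter of two such steps

Compound 4 gives > 100000 nM, which is a limit of the assay and not a number.

The change therefore does not carry from one core to the other on this read-out, but the pair does not show what in the cores reverses the step, and both step sizes remain bounds only: the limit of > 100000 nM in this assay, at which 2 of the 4 values shown sit.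

Open, from the compounds shown here alone, is whether a hydroxy group or a fluorine atom in place of the same methoxy would follow the direction seen on either core. Also open, going by these compounds, is which direction the change would take on a third core, for example one carrying a dimethylamino group in place of the amine of compound 2.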